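A few compounds are considered here, and "the series" means these few. Any claim that something is new, unique, unknown or untested is made for them only; others in the source may bear on it.

Compound 1 `CC(=O)NC1CCC(CN2CCN(c3cc(=O)c4cc(C(F)(F)F)cc([N+](=O)[O-])c4s3)CC2)CC1` is examined in an ADME assay on cells (Hepatocyte, Mus musculus) for metabolic stability, with a stated time of 30 min (a higher number here means that more of the compound is left, a lower number that less of the compound is left), where compound 1 gives 94.9%. Going by the values given here, that is the highest of the three numbers known so far. Compound 2 `O=C(OC1CCC(CN2CCN(c3cc(=O)c4cc(C(F)(F)F)cc([N+](=O)[O-])c4s3)CC2)CC1)c1cccs1` gives 1.8%, and compound 3 `COc1ccc(C(=O)OC2CCC(CN3CCN(c4cc(=O)c5cc(C(F)(F)F)cc([N+](=O)[O-])c5s4)CC3)CC2)cc1` gives 31%. The step of a number 93.1 percentage points lower from compound 1 to compound 2 (beyond the scatter) and the step of a number 63.9 percentage points lower from compound 1 to compound 3 (beyond the scatter) show that each exchange of the acetamido group on the saturated ring carbon brought a large loss, while a number 29.2 percentage points higher from compound 2 to compound 3 (beyond the scatter) was a modest gain between the two esters.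

Compound 4 `O=c1cc(N2CCN(CC3CCCCC3)CC2)sc2c([N+](=O)[O-])cc(C(F)(F)F)cc12` has not yet been measured. It differs from compound 1 in one place: hydrogen in place of acetamido on a saturated ring carbon. Among the compounds with values here, no measured step replaces acetamido with hydrogen; the two steps from compound 1 bear on it only in that both altered the same saturated ring carbon and both were large losses. A downward step in this assay is therefore expected, though a smaller one than either measured step, since what enters here is a hydrogen atom rather than a ((thiophen-2-yl)carbonyl)oxy or ((4-methoxyphenyl)carbonyl)oxy group. The estimated value for compound 4 is 60%, with a range from 25% to 92%. The step this estimate implies is a number 34.9 percentage points lower from compound 1 to compound 4 (beyond the scatter).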

Compound 4, percent of the compound remaining: 80.6%
The estimate for compound 4 lay 20.6 percentage points below the measured number; the range from low to high includes it.
By their numbers in this assay, from the lowest: compound 2; then compound 3; then compound 4; then compound 1.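

Replacing the acetamido group with hydrogen on the saturated ring carbon gave, in this assay, a number 14.3 percentage points lower from compound 1 to compound 4 (beyond the scatter), a modest step that shows most of the stability of compound 1 does not depend on that group. The same position without any substituent also stands far from both esters, with a number 49.6 percentage points higher from compound 3 to compound 4 (beyond the scatter) and a number 78.8 percentage points higher from compound 2 to compound 4 (beyond the scatter), both large, so among these four compounds the deep losses go with the entry of the ((thiophen-2-yl)carbonyl)oxy and ((4-methoxyphenyl)carbonyl)oxy groups rather than with the departure of acetamido alone. No measurement is available that accounts for these differences.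

The compounds shown leave open whether the loss belongs to the ester link itself or to the thiophen-2-yl and 4-methoxyphenyl groups it carries, which an amide bearing the same thiophen-2-yl carbonyl group on that ring carbon would separate. They also leave open where a hydroxyl group, a primary amine or a carboxylic acid at this position would fall relative to the acetamido and hydrogen compounds.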